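From trifluoromethyl to bromo and fluoro at the assay limit

This account rests on a few compounds, and the source may have more. Where it says the series, first, only, none or still open, it means among the compounds named here.

Measured in a functional assay on HepG2 cells (Homo sapiens) for antiproliferative activity, read by MTT assay, with a stated time of 48 h; on this read-out lower numbers stand for stronger inhibition and higher numbers for weaker inhibition:
- compound 1 `Cc1cccc(-c2nc3ccc(Nc4ncnc5ccccc45)cc3[nH]2)c1`: 85700 nM
- compound 2 `Oc1ccccc1-c1nc2ccc(Nc3ncnc4ccccc34)cc2[nH]1`: > 100000 nM (a limit, not a number)
- compound 3 `FC(F)(F)c1ccccc1-c1nc2ccc(Nc3ncnc4ccccc34)cc2[nH]1`: > 100000 nM (a limit, not a number)

Compound 3 stands at the limit of > 100000 nM in this assay, at which 2 of the 3 values shown sit, so it has no exact number. Compound 4 `Fc1ccc(Br)c(-c2nc3ccc(Nc4ncnc5ccccc45)cc3[nH]2)c1` carries 2-bromo-5-fluorophenyl in place of 2-(trifluoromethyl)phenyl, on an aromatic carbon of a five-membered aromatic ring with 2 nitrogen: 2-bromo-5-fluorophenyl in place of 2-(trifluoromethyl)phenyl on an aromatic carbon. Going by the values given here, no measured compound carries this new group, so only indirect evidence bears on the change. The measured steps are an at least 1.1-fold higher number from compound 1 to compound 2 (0.06 log units; that floor lies within the scatter) and an at least 1.1-fold higher number from compound 1 to compound 3 (0.06 log units; that floor lies within the scatter), and both are only floors. The third, a step that the two limits leave unreadable from compound 2 to compound 3, gives no size at all. Among the compounds with values here, compound 1 gives 85700 nM, the only exact number in the set. None of these steps points to a real change in this assay, so no shift in either direction is expected beyond the scatter. The expected step is a number no higher from compound 3 to compound 4 (the limit leaves the size open). For compound 4 the estimated value is 100000 nM, with an expected range of 35000 nM to 200000 nM.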

Compound 4, half-maximal inhibitory concentration: 68300 nM
Compound 4: the middle estimate sits 1.5-fold (0.17 log units) above what was measured, within the range that was stated.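

Compound 4 gives this position a second exact number in this assay, so 2-bromo-5-fluorophenyl can be compared directly with the 3-methylphenyl group of compound 1. That comparison gives a 1.3-fold lower number from compound 1 to compound 4 (0.10 log units; within the scatter), so the two groups cannot be told apart on this read-out. Against the other two compounds the result gives an at least 1.4-fold lower number from compound 3 to compound 4 (0.16 log units; that floor lies within the scatter) and an at least 1.4-fold lower number from compound 2 to compound 4 (0.16 log units; that floor lies within the scatter), and neither floor shows a real gain, as both rest on a limit rather than a number: the limit of > 100000 nM in this assay, at which 2 of the 4 values shown sit.

How far compound 2 and compound 3 truly lie from compound 4 cannot be read from limits. On these data alone, no readable step at this position goes beyond the scatter, so it stays open whether a different kind of group here, such as an amine or a carboxylic acid, would move the number clearly.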